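Working notes: chloro to cyano in compound 3

The compounds below may be only part of what the source reports. "The series", "measured", "known", "first", "only" and "open" are said of these compounds alone.

In a functional assay on HeLa cells (Homo sapiens) for cytotoxicity, read by MTT assay, with a stated time of 24 h (a higher number here means a weaker inhibitor, a lower number a stronger inhibitor), compound 2 (`COc1cc(/C=C2\CN(C)C/C(=C\c3ccc(Cl)cc3)C2=O)cc(OC)c1`) gives 11200 nM and holds the higher of the two measured numbers. Compound 1 (`CN1C/C(=C\c2ccc(C#N)cc2)C(=O)/C(=C/c2ccccc2F)C1`) gives 1340 nM in this assay and sits below compound 2 by a gap beyond the scatter. These two compounds differ in more than one place, so no single change can be read from that gap.

Compound 3 (`COc1cc(/C=C2\CN(C)C/C(=C\c3ccc(C#N)cc3)C2=O)cc(OC)c1`) has cyano in place of chloro on an aromatic carbon, which reads as 4-chlorophenyl to 4-cyanophenyl. Among the compounds with values here, compound 1 also carries 4-cyanophenyl and gives 1340 nM as the only guide, a weak one.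

A modest drop is expected in this assay, with a 2.5-fold lower number from compound 2 to compound 3 (0.40 log units; beyond the scatter) as the estimated step toward a stronger inhibitor. For compound 3 the estimated value is 4500 nM within an expected range of 1500 nM to 12000 nM for now.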

Compound 3, half-maximal inhibitory concentration: 3420 nM
Compound 3: the middle estimate sits 1.3-fold (0.12 log units) above what was measured; the range from low to high includes it.
By their numbers in this assay, from the lowest: compound 1; then compound 3; then compound 2.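

In this assay, within the data shown here, cyano in place of chloro on an aromatic carbon gives a 3.3-fold lower number from compound 2 to compound 3 (0.52 log units; beyond the scatter) and provides the first change that can be read at a single place. The position para to a large group therefore responds to the exchange of 4-chlorophenyl for 4-cyanophenyl, with the rest of the structure held constant. The data offer no measured explanation for this step.

On these data alone, the gaps involving compound 1 cannot be read as single changes, so it remains open whether the same exchange would give a similar step on the core of compound 1. Also open, as far as these compounds go, is how an amine or a carboxylic acid at this same position would compare with chloro and cyano on the shared core of compound 2 and compound 3.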